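The source may hold more compounds than are shown below. What is called first, only, known or untested is meant among the compounds shown, and "the series" means these compounds.

Measured compounds:
Compound 1 `O=c1cc(/C=N\Nc2ccc([N+](=O)[O-])cc2)c2ccc(OCc3ccccc3)cc2o1`. In a functional assay, read by spectrophotometry, with a stated time of 1 h (a lower number here means a stronger inhibitor, a higher number a weaker inhibitor), compound 1 gives only a limit, > 2000000 nM.
Compound 2 `O=c1cc(/C=N\Nc2ccccc2)c2ccc(OCc3ccccc3)cc2o1`. In this assay compound 2 gives 455000 nM.
Compound 3 `O=c1cc(/C=N\Nc2ccc([N+](=O)[O-])cc2)c2c(OCc3ccccc3)cc(OCc3ccccc3)cc2o1`. In this assay compound 3 gives 97900 nM.

Compound 1 and compound 2 differ by hydrogen in place of nitro on an aromatic carbon; this change made an at least 4.3-fold lower number from compound 1 to compound 2 (0.64 log units; beyond the scatter). The size of that step rests on the limit of compound 1, (the limit of > 2000000 nM in this assay, at which 1 of the 3 values shown sits). The cores of compound 1 and compound 3 differ by benzyloxy in place of hydrogen on an aromatic carbon, a change that gave an at least 20-fold lower number from compound 1 to compound 3 (1.31 log units; beyond the scatter).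

Compound 4 `O=c1cc(/C=N\Nc2ccccc2)c2c(OCc3ccccc3)cc(OCc3ccccc3)cc2o1` is not yet measured. It differs from compound 3 by hydrogen in place of nitro on an aromatic carbon, the same change as from compound 1 to compound 2, at the same place. The step is expected to be a 4.5-fold lower number from compound 3 to compound 4 (0.65 log units; beyond the scatter), resting on an at least 4.3-fold lower number from compound 1 to compound 2 (0.64 log units; beyond the scatter), which is itself only a bound. Compound 4 is therefore estimated at 22000 nM, with a plausible range from 5000 nM to 80000 nM.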

Compound 4, half-maximal inhibitory concentration: 401000 nM
Compound 4: the middle estimate sits 18-fold (1.26 log units) below what was measured, and the stated range ends below it.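

In this assay, hydrogen in place of nitro gave a 4.1-fold higher number from compound 3 to compound 4 (0.61 log units; beyond the scatter), so this change does not carry from one core to the other: the same change on two cores in this assay, an at least 4.3-fold lower number (0.64 log units; beyond the scatter) from compound 1 to compound 2 and a 4.1-fold higher number (0.61 log units; beyond the scatter) from compound 3 to compound 4, at least 18-fold (1.25 log units) apart, beyond the scatter of two such steps. Benzyloxy in place of hydrogen gave a 1.1-fold lower number from compound 2 to compound 4 (0.05 log units; within the scatter), so that change does not carry between the two cores either: the same change on two cores in this assay, an at least 20-fold lower number (1.31 log units; beyond the scatter) from compound 1 to compound 3 and a 1.1-fold lower number (0.05 log units; within the scatter) from compound 2 to compound 4, at least 18-fold (1.25 log units) apart, beyond the scatter of two such steps. Both gaps are only bounds, and the four compounds do not show why the steps differ, with compound 1 resting on a limit rather than a number: the limit of > 2000000 nM in this assay, at which 1 of the 4 values shown sits.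

Open, from the compounds shown here alone, is whether the reversal also appears with an amine or a carboxylic acid in place of nitro on the phenyl ring. Also open, going by these compounds, is whether either step holds with methoxy in place of benzyloxy.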